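Sulfur to selenium swap on compound 2

This account rests on a few compounds, and the source may have more. Where it says the series, first, only, none or still open, it means among the compounds named here.

Among the measured compounds shown here, compound 2 `Cc1noc(C)c1CSC#N` holds the lowest number of the two measured so far: in a functional assay on PC-3 cells (Homo sapiens) for cytotoxicity, read by MTT assay, with a stated time of 72 h (a lower number here means a stronger inhibitor of growth, a higher number a weaker inhibitor of growth), compound 2 gives 8000 nM. The nearest value belongs to compound 1 `N#CSc1nc2ccccc2s1`, and in this assay compound 1 gives 42000 nM, a gap beyond the scatter. Compound 3 `Cc1noc(C)c1C[Se]C#N` differs from compound 2 in one place: a group of 3 heavy atoms (1 carbon, 1 nitrogen, 1 selenium; no ring) in place of a group of 3 heavy atoms (1 carbon, 1 nitrogen, 1 sulfur; no ring), on a saturated chain carbon bound to an aromatic carbon. For the measured compounds named here, no measured pair shows this exchange, so its step size is unknown. In this assay a modest move toward a lower number is expected, not far beyond the scatter. Compound 3 is estimated at 4000 nM, with a range from 1000 nM to 16000 nM. The estimated step of a 2.0-fold lower number from compound 2 to compound 3 (0.30 log units; within the scatter) is expected to be small.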

Compound 3, concentration for 50% growth inhibition: 5600 nM
For compound 3 the middle estimate is 1.4-fold (0.15 log units) below the measured one; low and high end bracket the measured number.
By their numbers in this assay, from the lowest: compounds 3 and 2 (each within the scatter of the next); then compound 1.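

In this assay, selenium in place of sulfur on a saturated chain carbon bound to an aromatic carbon gives a 1.4-fold lower number from compound 2 to compound 3 (0.15 log units; within the scatter), so the two compounds cannot be told apart. This first measured pair at the position shows that the exchange leaves the number within the scatter, and it speaks for this one pair only. No supporting data on the result are available.

Still open, on these data alone, is whether the same exchange behaves alike on the core of compound 1. Also open, as far as these compounds go, is what an amine or a methylthio group would do in place of the cyanosulfanyl group.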